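The source may report more compounds than this note shows. Statements on the series, on what has been measured and on what is new or still open speak of the compounds shown alone.

Measured so far:
- compound 1 `COc1ccc(F)cc1CNCCCNc1ccnc2cc(C3CCCCC3)ccc12`: 4200 nM
- compound 2 `COc1cccc(CNCCCNc2ccnc3cc(-c4ccc(C(F)(F)F)cc4)ccc23)c1O`: 32000 nM
- compound 3 `COc1ccc(-c2ccc3c(NCCCNCc4ccco4)ccnc3c2)cc1`: 32000 nM

In a physicochemical assay for solubility, with a stated time of 18 h, at pH 7.4 (on this read-out higher numbers stand for higher solubility and lower numbers for lower solubility), compound 1 stands lowest of the three numbers; compound 2 and compound 3 each give a higher reading, in both cases beyond the scatter. Compound 4 `COc1ccc(F)cc1CNCCCNc1ccnc2cc(-c3ccccc3)ccc12` has not yet been measured. It differs from compound 1 in one place: phenyl in place of cyclohexyl on an aromatic carbon. For the measured compounds named here, no pair of measured compounds carries this same change, so the size of the step is not known from the data. Compound 2 and compound 3 both carry a substituted phenyl ring and both read higher than compound 1, but they also differ from compound 1 elsewhere. A modest rise, beyond the scatter, is expected a 2.1-fold higher number from compound 1 to compound 4 (0.33 log units; beyond the scatter). Compound 4 is estimated at 9000 nM, within 3000 nM to 27000 nM.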

Compound 4, solubility: 32000 nM
Estimate against measurement, compound 4: 3.6-fold (0.55 log units) below, and the stated range ends below it.
By their numbers in this assay, from the lowest: compound 1; then compounds 2, 3 and 4 (each within the scatter of the next).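

In this assay, for the compounds shown here, phenyl in place of cyclohexyl on an aromatic carbon of the shared core gives a 7.6-fold higher number from compound 1 to compound 4 (0.88 log units; beyond the scatter) and is the first single-place step read at this position. The two groups match in heavy-atom count and neither has hydrogen-bond donors or acceptors, so the step goes with the change from a non-aromatic to an aromatic ring. No measurement shown gives a reason for the size of this step.

Still open, as far as these compounds go, is how a pyridyl ring or a morpholine would read at this position. Also open, from the compounds shown here alone, is whether the step holds when the rest of compound 4 changes.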